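The source may report more compounds than this note shows. Statements on the series, on what has been measured and on what is new or still open speak of the compounds shown alone.

Compound 1 `COCc1cc(CCCOc2c(C)cc(-c3noc(C4CC4)n3)cc2C)on1` gives > 2.5 h in an in vitro ADME assay on microsomes from liver (Simiiformes) (a higher number here means that the compound lasts longer, a lower number that the compound disappears faster), and this is a limit of the assay, not a number. In this assay compound 2 `CC(=O)c1ccc(CCCOc2c(C)cc(-c3noc(C(F)(F)F)n3)cc2C)o1` gives 1.05 h and compound 3 `Cc1cc(CCCOc2c(C)cc(-c3noc(CC(F)(F)F)n3)cc2C)on1` gives 0.533 h. These two values lie within the scatter of each other, so compound 3 stands with compound 2 on the numbers available.

The next analogue, compound 4 `Cc1cc(CCCOc2c(C)cc(-c3noc(C(Cl)(Cl)Cl)n3)cc2C)on1`, carries trichloromethyl in place of 2,2,2-trifluoroethyl on an aromatic carbon. Among the compounds with values here, no measured pair isolates a change at this place, so the size of the step has no direct precedent. Compounds 2 and 3 differ in more than one place, yet compound 2 at 1.05 h and compound 3 at 0.533 h remain within the scatter, so no step beyond the scatter is expected in this assay. The estimated change is a 1.1-fold higher number from compound 3 to compound 4 (0.05 log units; within the scatter), with either direction possible. For compound 4 the expected half-life is 0.6 h, with an estimated range of 0.25 h to 1.4 h.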

Compound 4, half-life: 0.183 h
Compound 4: middle estimate off by 3.3-fold (0.52 log units), on the high side, outside the stated range (below it).
By their numbers in this assay, from the lowest: compound 4; then compounds 3 and 2 (each within the scatter of the next). At a limit, above all of these: compound 1.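

In this assay, within the data shown here, the change to trichloromethyl in place of 2,2,2-trifluoroethyl gives a 2.9-fold lower number from compound 3 to compound 4 (0.46 log units; beyond the scatter) as the first step that isolates a single place. The group on this aromatic carbon, next to the ring nitrogen and the ring oxygen, can therefore shift the half-life beyond the scatter, and here the compound disappears faster. Nothing in the data at hand accounts for this step.

This single pair gives no trend across groups at this place, and it does not show whether the step would carry over to the other compounds, which differ in more than one place. On these data alone, how an amine, a carboxylic acid or a longer chain at this position would compare with 2,2,2-trifluoroethyl remains open.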